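The compounds below may be only part of what the source reports. "The series", "measured", "known", "first", "only" and "open" are said of these compounds alone.

Measured so far in a functional assay on K562 cells (Homo sapiens) for inhibition, read by trypan blue exclusion, with a stated time of 72 h; on this read-out lower numbers stand for stronger inhibition and higher numbers for weaker inhibition:
- compound 1 `Cn1c(=O)c(S(=O)(=O)c2ccc(F)cc2F)cc2cnc(Nc3ccc4[nH]c(C(=O)O)cc4c3)nc21` gives 10000 nM
- compound 2 `COC(=O)Cn1c(=O)c(S(=O)(=O)c2ccc(F)cc2F)cc2cnc(Nc3ccc4[nH]ccc4c3)nc21` gives 5000 nM
- compound 3 `Cn1c(=O)c(S(=O)(=O)c2ccccc2)cc2cnc(Nc3ccc4ncccc4c3)nc21` gives 100000 nM

Compound 1 and compound 2 lie within the scatter of each other, so the two cannot be ranked. Compound 1 has a lower number than compound 3, and that gap is beyond the scatter.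

Compound 4 `Cn1c(=O)c(S(=O)(=O)c2ccc(F)cc2F)cc2cnc(Nc3ccc4occc4c3)nc21` is still unmeasured. It differs from compound 1 as follows: 1-benzofuran-5-yl in place of 2-carboxy-1H-indol-5-yl on a nitrogen on an aromatic ring. In words, 1-benzofuran-5-yl stands in place of 2-carboxy-1H-indol-5-yl on a nitrogen on an aromatic ring.

For the measured compounds named here, no measured pair isolates a change in one place, so the expectation is loose. It rests on compound 2 at 5000 nM and on compound 3 at 100000 nM as the spread seen so far. The expected change is a 2.5-fold lower number from compound 1 to compound 4 (0.40 log units; beyond the scatter), a small step toward a lower number in this assay. For compound 4 the estimated value is 4000 nM with an expected range from 700 nM to 20000 nM as the measurement is awaited.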

Compound 4, half-maximal inhibitory concentration: 15000 nM
Compound 4: middle estimate off by 3.8-fold (0.57 log units), on the low side; low and high end bracket the measured number.
By their numbers in this assay, from the lowest: compounds 2, 1 and 4 (each within the scatter of the next, the first and the last beyond it); then compound 3.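

In this assay, for the compounds shown here, 1-benzofuran-5-yl in place of 2-carboxy-1H-indol-5-yl on a nitrogen on an aromatic ring gives a 1.5-fold higher number from compound 1 to compound 4 (0.18 log units; within the scatter), the first step that isolates a change at this position. This single swap takes the count of hydrogen-bond donors in the group from 2 to 0 and leaves the group with fewer heavy atoms, yet compound 1 and compound 4 cannot be ranked, so at this position this read-out does not separate the two groups. Nothing on hand accounts for this outcome.

From the compounds shown here alone, the swap removes the carboxy group and changes the ring hetero atom together, so the share of each stays open. Also open, going by these compounds, is whether a primary amide or an aminomethyl group on this bicyclic group would shift the number beyond the scatter.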